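The source may hold more compounds than are shown below. What is called first, only, known or untested is meant among the compounds shown, and "the series" means these compounds.

Measured so far in a functional assay on Bel7402/5-FU cells (Homo sapiens) for antiproliferative activity, read by MTT assay, with a stated time of 72 h; on this read-out higher numbers stand for weaker inhibition and lower numbers for stronger inhibition:
- compound 1 `C=C1C(=O)O[C@H]2[C@H]1CC/C(COC(=O)CCC(=O)N1CCN(C(=O)Cn3cc(F)c(=O)[nH]c3=O)CC1)=C\CC[C@@]1(C)O[C@@H]21` gives > 20000 nM (a limit)
- compound 2 `C=C1C(=O)O[C@H]2[C@H]1CC/C(COC(=O)CCC(=O)N1CCN(C(=O)Cn3cc(F)c(=O)n(Cc4ccccc4)c3=O)CC1)=C\CC[C@@]1(C)O[C@@H]21` gives > 20000 nM (a limit)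
- compound 3 `C=C1C(=O)O[C@H]2[C@H]1CC/C(COC(=O)Cn1cc(F)c(=O)n(Cc3ccc(F)cc3)c1=O)=C\CC[C@@]1(C)O[C@@H]21` gives 1140 nM (a number)

Compound 3 is the only one of the three with a true number, while the other two stand at the limit of > 20000 nM in this assay, at which 2 of the 3 values shown sit, and not at a measured value. Compound 4 `C=C1C(=O)O[C@H]2[C@H]1CC/C(COC(=O)Cn1cc(F)c(=O)n(Cc3cccc(F)c3)c1=O)=C\CC[C@@]1(C)O[C@@H]21` has not yet been measured. The change from compound 3 is 3-fluorophenyl in place of 4-fluorophenyl on a saturated chain carbon bound to an aromatic nitrogen, which amounts to 4-fluorobenzyl becoming 3-fluorobenzyl.

Within the data shown here, the only measured step is a step that the two limits leave unreadable from compound 1 to compound 2 and it concerns benzyl in place of hydrogen on an aromatic nitrogen. Among the measured compounds shown here, it offers no size to carry over, and no measured step involves moving the fluorine. The best anchor is therefore compound 3 at 1140 nM, with no shift expected in either direction beyond the usual scatter of this assay. The expected change is a 1.1-fold higher number from compound 3 to compound 4 (0.02 log units; within the scatter) and it could fall either way. For compound 4 the estimated value is 1200 nM, with an expected range of 450 nM to 3200 nM.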

Compound 4, half-maximal inhibitory concentration: 3700 nM
Beside the measured number, compound 4's estimate is 3.1-fold (0.49 log units) below it, outside the stated range (above it).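

In this assay, among these compounds, moving the fluorine on the benzyl group matters: 4-fluorobenzyl becoming 3-fluorobenzyl gives a 3.2-fold higher number from compound 3 to compound 4 (0.51 log units; beyond the scatter) and is the first step here that can be read, the earlier step between two limits being unreadable. The two groups have the same atoms joined differently, so this position responds to where the fluorine sits and not only to whether it is present. Nothing measured here explains the difference.

The compounds shown leave open how a benzyl group with no fluorine would read on the linker of compound 3. They also leave open whether a chlorine or a methoxy group on the benzyl ring, or a pyridylmethyl group in its place, would give a lower number than compound 3 1140 nM on this read-out.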